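Replacing nitro with methoxy on the amide-bearing phenyl ring

The source may hold more compounds than are shown below. What is called first, only, known or untested is meant among the compounds shown, and "the series" means these compounds.

The series is followed in an assay on CHO cells for positive allosteric modulation of metabotropic glutamate receptor 5 (Homo sapiens), read by FLIPR; a higher number here means that more compound is needed for the effect, a lower number that less compound is needed. Among the compounds with values here, compound 1 `O=C(Nc1ccc(Cl)cc1CN1C(=O)c2ccccc2C1=O)c1ccccc1[N+](=O)[O-]` gives 5700 nM in this assay, the highest of the two numbers known so far. Within the data shown here, compound 2 `O=C(Nc1ccc(Cl)cc1CN1C(=O)c2ccc(F)cc2C1=O)c1ccccn1` gives 330 nM in this assay, a lower number than compound 1 by a margin that lies beyond the scatter; compound 2 differs from compound 1 in more than one place, so no single step between them can be read off.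

Compound 3 `COc1ccccc1C(=O)Nc1ccc(Cl)cc1CN1C(=O)c2ccccc2C1=O` has not been measured. It differs from compound 1 in one place: methoxy in place of nitro on an aromatic carbon

Among the measured compounds shown here, no step between two measured compounds shows the effect of this change on its own. Because compound 1 gives 5700 nM in this assay, there is room for the number to fall, and a small improvement is expected, of a size at or close to the edge of the scatter. Compound 3 is estimated at 3000 nM in this assay, with a range from 900 nM to 10000 nM. The expected step of a 1.9-fold lower number from compound 1 to compound 3 (0.28 log units; within the scatter) is therefore small, and it may turn out to be no step beyond the scatter at all.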

Compound 3, half-maximal effective concentration: > 100000 nM
Compound 3: only a limit was reported (the forecaster's own chance of this, stated with the estimate: 15%); middle value at least 33-fold (1.52 log units) away from the limit.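

In this assay compound 3 gives > 100000 nM, which is a limit of the assay and not a number. Methoxy in place of nitro gives an at least 17-fold higher number from compound 1 to compound 3 (1.24 log units; beyond the scatter), the first single-place step in the series, and it shows that this aromatic carbon, ortho to a large group, is far from indifferent to what it carries: two groups with no ring and no net charge, and with no hydrogen-bond donors, still lie a large step apart. How far the true number of compound 3 lies past that point cannot be read, so the step gives only the least size of the loss: the limit of > 100000 nM in this assay, at which 1 of the 3 values shown sits.

What the compounds shown leave open is whether nitro is special at this place or methoxy alone is the poor choice, and a fluorine, a nitrile, an amine or a carboxylic acid on the same carbon would separate those two readings. Also open, from the compounds shown here alone, is whether the same swap costs as much on a core carrying the fluorine of compound 2, since that compound differs from compound 1 in more than one place.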